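Chloro added to a tolerated series of three

A few compounds are considered here, and "the series" means these few. Any claim that something is new, unique, unknown or untested is made for them only; others in the source may bear on it.

Compound 1 `CC(=O)OC[C@H]1O[C@@H](CC(=O)/C=C2\C(=O)N(Cc3ccccc3)c3ccccc32)[C@H](OC(C)=O)[C@@H](OC(C)=O)[C@@H]1OC(C)=O`: 71200 nM
Compound 2 `CC(=O)OC[C@H]1O[C@@H](CC(=O)/C=C2\C(=O)N(Cc3ccc(Br)cc3)c3ccccc32)[C@H](OC(C)=O)[C@@H](OC(C)=O)[C@@H]1OC(C)=O`: 76500 nM
Compound 3 `CC(=O)OC[C@H]1O[C@@H](CC(=O)/C=C2\C(=O)N(Cc3cccc(C)c3)c3ccccc32)[C@H](OC(C)=O)[C@@H](OC(C)=O)[C@@H]1OC(C)=O`: 72500 nM

These values come from an ADME assay on Vero cells (Chlorocebus sabaeus) for cytotoxicity, read by resazurin assay, with a stated time of 72 h; a higher number here means that more compound is tolerated, a lower number that less compound is tolerated. In this assay, compound 3 stands at 72500 nM, within the scatter of both compound 1 and compound 2, so the three cannot be ranked.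

Compound 4 `CC(=O)OC[C@H]1O[C@@H](CC(=O)/C=C2\C(=O)N(Cc3cccc(C)c3)c3ccc(Cl)cc32)[C@H](OC(C)=O)[C@@H](OC(C)=O)[C@@H]1OC(C)=O` carries chloro in place of hydrogen on an aromatic carbon of compound 3: chloro in place of hydrogen on an aromatic carbon.

Two measured steps resemble this change. Bromo in place of hydrogen on an aromatic carbon gave a 1.1-fold higher number from compound 1 to compound 2 (0.03 log units; within the scatter), and methyl in place of hydrogen on an aromatic carbon gave a 1.0-fold higher number from compound 1 to compound 3 (0.01 log units; within the scatter). The exchange of the two substituted rings gave a 1.1-fold lower number from compound 2 to compound 3 (0.02 log units; within the scatter). Among the compounds with values here, none of these steps touches the ring that takes the chloro, so the data offer no direct precedent there. No step beyond the scatter is therefore expected, although the uncertainty is wider than the measured steps alone suggest.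

The expected change is a 1.1-fold lower number from compound 3 to compound 4 (0.03 log units; within the scatter). For compound 4 the estimated value is 68000 nM, with an expected range of 38000 nM to 100000 nM.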

Compound 4, half-maximal cytotoxic concentration: 91000 nM
Estimate against measurement, compound 4: 1.3-fold (0.13 log units) below; the measured number falls inside the stated range.
By their numbers in this assay, from the lowest: compounds 1, 3, 2 and 4 (each within the scatter of the next).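

In this assay, chloro in place of hydrogen on the six-membered aromatic ring of carbon only, part of a fused or bridged system of two rings, gave a 1.3-fold higher number from compound 3 to compound 4 (0.10 log units; within the scatter) and so stayed within the scatter. This is the first step among these compounds to touch that ring, and it shows that this position, meta to a fused ring and para to a fused ring, can carry chloro without a step beyond the scatter in this cell read-out. No measured evidence bears on why this step is so small.

As far as these compounds go, it remains open whether a different group at this carbon, such as an amine, a carboxylic acid or a longer chain, would also stay within the scatter. The compounds shown also leave open whether chloro would give a similar step on compound 1 or compound 2.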